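Cyclohexyloxy in Place of Methoxy on a Benzamide Inhibitor

A few compounds are considered here, and "the series" means these few. Any claim that something is new, unique, unknown or untested is made for them only; others in the source may bear on it.

Of the compounds shown here, three sharing a benzamide core have been measured in an assay on isolated protein for inhibition of phosphodiesterase 4A (Sus scrofa); on this read-out lower numbers stand for stronger inhibition and higher numbers for weaker inhibition. Compound 3 `COc1ccc(C(=O)Nc2c(Cl)cncc2Cl)cc1OC` gives 100 nM, the lowest of the three numbers. Compound 1 `COc1ccc(C(=O)Nc2c(F)cccc2F)cc1OC1CCCCC1` gives 400 nM, and compound 2 `COc1ccc(C(=O)Nc2ccccn2)cc1OC1CCCC1` gives 1000 nM; both gaps to compound 3 are beyond the scatter, so compound 3 stands as the strongest inhibitor among the measured compounds.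

Compound 4 `COc1ccc(C(=O)Nc2c(Cl)cncc2Cl)cc1OC1CCCCC1` has not yet been measured. It differs from compound 3 in one place: cyclohexyl in place of methyl on an oxygen on an aromatic ring, which one bond further out reads as methoxy to cyclohexyloxy. Among the measured compounds shown here, no measured pair isolates this exchange. Compound 1 and compound 2 do carry a ring on that oxygen, but each combines it with a different amide partner than compound 3, so their values show only what they show and give no direct measure of the change.

The step from compound 3 to compound 4 is expected to move toward stronger inhibition, with a size beyond the scatter, as a 10-fold lower number from compound 3 to compound 4 (1.00 log units; beyond the scatter). Compound 4 is therefore estimated at 10 nM, with a range from 2 nM to 50 nM.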

Compound 4, half-maximal inhibitory concentration: 50 nM
Estimate against measurement, compound 4: 5.0-fold (0.70 log units) below; measured number inside the range.
By their numbers in this assay, from the lowest: compounds 4 and 3 (each within the scatter of the next); then compound 1; then compound 2.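

In this assay, the exchange of methyl for cyclohexyl on the oxygen on the aromatic ring can now be read directly, and it gives a 2.0-fold lower number from compound 3 to compound 4 (0.30 log units; within the scatter). Among the compounds shown here, the position therefore takes the cyclohexyl ring with no change in this read-out beyond the scatter, which the earlier compounds could not show, since each of them carried a different amide partner. With cyclohexyloxy held constant, the exchange of 2,6-difluorophenyl for 3,5-dichloropyridin-4-yl on the amide-type nitrogen gives an 8.0-fold lower number from compound 1 to compound 4 (0.90 log units; beyond the scatter), so in this pair the amide partner moves the number beyond the scatter; no measurement at hand accounts for either step.

This single pair does not tell whether the same exchange would read alike with another amide partner, such as the 2,6-difluorophenyl of compound 1 or the pyridin-2-yl of compound 2. It also leaves open whether a group of another kind on this oxygen, such as a benzyl group or a straight butyl chain, would be taken up in the same way.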